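Removing an Acetyl From a Cytotoxic Polyketide Lactone

A few compounds are considered here, and "the series" means these few. Any claim that something is new, unique, unknown or untested is made for them only; others in the source may bear on it.

Among the measured compounds shown here, compound 2, `C=C/C=C\[C@H](C)[C@H](OC(N)=O)[C@@H](C)[C@H](O)[C@@H](C)C/C(C)=C\[C@H](C)[C@@H](OC(C)=O)[C@@H](C)/C=C\[C@@H](O)C[C@@H]1OC(=O)C(C)=C[C@H]1C`, is the only member of this set with a numerical result: in a functional assay on A549 cells (Homo sapiens) for cytotoxicity (a higher number here means a weaker inhibitor, a lower number a stronger inhibitor), compound 2 gives 3130 nM, and that value stands alone, with nothing to compare it against among the measured entries. Compound 1, `CCCC[C@H](C)[C@H](OC(N)=O)[C@@H](C)[C@H](OC(C)=O)[C@@H](C)C/C(C)=C\[C@H](C)[C@@H](OC(C)=O)[C@@H](C)CCCC[C@@H]1OC(=O)[C@H](C)[C@@H](OC(C)=O)[C@H]1C`, belongs to the same series, but in this assay compound 1 has "not determined" (no result reported), so compound 2 cannot be placed relative to anything else. Compound 3, `C=C/C=C\[C@H](C)[C@H](OC(N)=O)[C@@H](C)[C@H](O)[C@@H](C)C/C(C)=C\[C@H](C)[C@@H](O)[C@@H](C)/C=C\[C@@H](O)C[C@@H]1OC(=O)C(C)=C[C@H]1C`, is the next compound to be measured. It differs from compound 2 in one place: hydrogen in place of acetyl on an oxygen on a saturated carbon, which, cut one bond further out, reads acetoxy to hydroxy. For the measured compounds named here, since no pair of measured compounds differing in one place is available, the size of this step cannot be read from the data. The writer expects a modest step, most likely a loss of potency that may exceed the usual scatter, but with a real chance of no change beyond it. Compound 3 is thus expected to show 6000 nM, with a range from 2000 nM to 20000 nM. The estimated step of a 1.9-fold higher number from compound 2 to compound 3 (0.28 log units; within the scatter) reflects that expectation.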

Compound 3, half-maximal inhibitory concentration: 21.7 nM
For compound 3 the middle estimate is 280-fold (2.44 log units) above the measured one; measured number outside the range, below it.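

In this assay, among the compounds shown here, the single exchange of acetoxy for hydroxy, with hydrogen in place of acetyl on an oxygen on a saturated carbon, gives a 140-fold lower number from compound 2 to compound 3 (2.16 log units; beyond the scatter). For the compounds shown here, this is the first reading of this position, and it shows that the position is far from indifferent: the two compounds differ nowhere else, so the whole of this large step goes with the loss of the acetyl and the freeing of the hydroxy, and the free hydroxy form is clearly the more potent of the pair in this cell assay. Nothing in the data shown explains how this exchange produces so large a step.

Going by these compounds alone, two compounds give only one step, so it remains open whether any group on this oxygen other than hydrogen is tolerated, for example a methyl ether, a formyl or a longer acyl chain such as butyryl, or whether acetyl alone is so much worse than hydrogen here. From the compounds shown here alone, compound 1 offers no number, so steps involving it cannot be read, and the same exchange at the other oxygens of the shared core remains untested in these compounds.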